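A few compounds are considered here, and "the series" means these few. Any claim that something is new, unique, unknown or untested is made for them only; others in the source may bear on it.

Measured compounds:
compound 1 `Cc1ccc2ncc(S(=O)(=O)c3ccc(Cl)cc3)c(N3CCC(C)CC3)c2c1`, 79%
compound 2 `CC1CCN(c2c(S(=O)(=O)c3cccc(C#N)c3)cnc3cc(Cl)ccc23)CC1`, 94%
compound 3 `Cc1ccc(S(=O)(=O)c2cnc3ccc(Cl)cc3c2N2CCC(C)CC2)cc1Cl`, 81%

All three were tested in an assay on isolated protein for displacement of a labelled ligand from metabotropic glutamate receptor 5 (Homo sapiens), with a stated time of 60 min, tested at 1 uM; on this read-out higher numbers stand for more inhibition at the one concentration tested (going by the name of the read-out) and lower numbers for less inhibition. Compound 2 gives 94%, the highest of the three numbers; the nearest is compound 3 with 81%, and compound 1 sits furthest away with 79%, both gaps lying beyond the usual scatter.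

Compound 4 `CC1CCN(c2c(S(=O)(=O)c3ccc(C#N)cc3)cnc3cc(Cl)ccc23)CC1` is not yet measured. It keeps every atom of compound 2 but joins them differently: 4-cyanophenyl in place of 3-cyanophenyl on a sulfonyl sulfur. Nothing measured here shows what this kind of rearrangement does. Compound 2 already sits near the top of the scale, so the step is expected to be small, or none beyond the scatter, with a lean downward. The estimate for compound 4 in this assay is 86% (range 66% to 97%), an expected step of a number 8 percentage points lower from compound 2 to compound 4 (within the scatter).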

Compound 4, a percentage reported as inhibition, at one concentration (the size of the read-out at that concentration, not a potency): 70%
Estimate against measurement, compound 4: 16 percentage points above, within the range that was stated.
By their numbers in this assay, from the lowest: compounds 4, 1 and 3 (each within the scatter of the next, the first and the last beyond it); then compound 2.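

Swapping 3-cyanophenyl for 4-cyanophenyl on a sulfonyl sulfur is enough by itself to change the result in this assay, giving a number 24 percentage points lower from compound 2 to compound 4 (beyond the scatter) here. The earlier compounds shown here differ from each other in more than one place, so they could not isolate any single change. Here the atoms stay the same and only how they are joined differs, which shows that the arrangement of this group matters. Nothing available explains the drop. On these data alone, whether a carboxylic acid or a primary amide could replace the nitrile on this ring remains open.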